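The source may hold more compounds than are shown below. What is called first, only, known or untested is meant among the compounds shown, and "the series" means these compounds.

Measured so far:
compound 1 `O=[N+]([O-])c1ccc(-c2nnc(C3CCc4cc(F)ccc4O3)o2)cc1`: in a functional assay (on this read-out lower numbers stand for stronger inhibition and higher numbers for weaker inhibition), compound 1 gives 84800 nM
compound 2 `Fc1ccc2c(c1)CCC(c1nnc(-c3ccccc3Cl)o1)O2`: in this assay compound 2 gives 88000 nM

Both numbers sit far up the scale, where inhibition is weak. Compound 2 stands beside compound 1 on these numbers, and the gap between the two lies within the usual scatter, so nothing separates them. The two share a core and differ only in the aromatic group that hangs from the five-membered ring, a nitrophenyl in compound 1 and a 2-chlorophenyl in compound 2; neither choice moved the read-out away from the other.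

Compound 3 `Fc1ccc2c(c1)CCC(c1nnc(-c3cnccn3)o1)O2` is the next step from compound 2. The change is pyrazin-2-yl in place of 2-chlorophenyl on an aromatic carbon. Within the data shown here, no measured pair in this set shows what such a swap does, so the expectation rests on the two weak numbers alone. The step from compound 2 to compound 3 is expected to amount to a 1.0-fold higher number from compound 2 to compound 3 (0.01 log units; within the scatter), which is no more than the scatter. On this basis compound 3 is expected to give about 90000 nM in this assay, within a range from 30000 nM to 250000 nM.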

Compound 3, half-maximal inhibitory concentration: 87000 nM
Estimate against measurement, compound 3: 1.0-fold (0.01 log units) above; low and high end bracket the measured number.
By their numbers in this assay, from the lowest: compounds 1, 3 and 2 (each within the scatter of the next).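

In this assay, among these compounds, the pair gives the first direct reading of this position, on an aromatic carbon of the five-membered aromatic ring: pyrazin-2-yl in place of 2-chlorophenyl amounts to a 1.0-fold lower number from compound 2 to compound 3 (0.00 log units; within the scatter). The entering group has a six-membered aromatic ring with 2 hetero atoms and 2 hydrogen-bond acceptors, whereas the leaving group has a ring of carbon only, a chlorine and 0 hydrogen-bond acceptors, yet the read-out does not separate the two compounds. No measurement on hand accounts for this flat result.

The compounds shown leave open whether any other group at this position could move the read-out out of the weak end of the scale, for example an aminomethyl group, a carboxylic acid or a longer alkyl chain in place of the six-membered aromatic ring. They also leave open whether a change elsewhere on the shared core, such as a hydroxyl group or a methoxy group in place of the fluorine, would shift the number at all.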